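Methylation of the phenol in compound 1: expected outcome

This account rests on a few compounds, and the source may have more. Where it says the series, first, only, none or still open, it means among the compounds named here.

Measured compounds:
compound 1 `COc1cc(OC)cc(-n2cc(-c3ccc(OC)c(O)c3)nn2)c1`, in a functional assay on MDA-MB-231 cells (Homo sapiens) for cytotoxicity, read by MTT assay (on this read-out lower numbers stand for stronger inhibition and higher numbers for weaker inhibition), compound 1 gives > 10000 nM
compound 2 `COc1ccc(-c2cn(-c3cc(OC)c(OC)c(OC)c3)nn2)cc1O`, in this assay compound 2 gives > 10000 nM
compound 3 `COc1ccc(-c2cn(-c3ccc(OC(F)(F)F)cc3)nn2)cc1OC`, in this assay compound 3 gives > 1000 nM

Where compound 1 stands: its value in this assay is a limit of the assay, not a number. The value of compound 2 in this assay is likewise a limit. The value of compound 3 in this assay is also a limit, though a different one. Within the data shown here, no compound in the set has a numerical reading, so compound 1 cannot be placed relative to the others beyond the statement that it sits at the limit described by the limit of > 10000 nM in this assay, at which 2 of the 3 values shown sit.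

The step from compound 1 to compound 2, methoxy in place of hydrogen on an aromatic carbon, gives a step that the two limits leave unreadable from compound 1 to compound 2, unreadable because both ends sit at the limit of > 10000 nM in this assay, at which 2 of the 3 values shown sit.

Compound 4 `COc1cc(OC)cc(-n2cc(-c3ccc(OC)c(OC)c3)nn2)c1` differs from compound 1 by methyl in place of hydrogen on an oxygen on an aromatic ring, that is, the hydroxy of compound 1 becomes a methoxy. Among the measured compounds shown here, no measured step covers this change. Compound 3, which carries two methoxy groups on the same ring and no hydroxy, sits at the limit of > 1000 nM in this assay, at which 1 of the 3 values shown sits, and the two hydroxy-bearing compounds sit at the limit of > 10000 nM in this assay, at which 2 of the 3 values shown sit.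

Nothing here points to a gain, so compound 4 is expected to remain at the limit, with an estimated 20000 nM, range 5000 nM to 80000 nM. The step from compound 1 to compound 4 is therefore expected to be a step that the limit leaves unreadable from compound 1 to compound 4, with the most likely result being another limit rather than a number.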

Compound 4, half-maximal inhibitory concentration: > 1000 nM
Compound 4: a limit, no number (the forecaster's own chance of this, stated with the estimate: 85%); the middle value does not contradict the limit.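

Compound 1 and compound 4 are both recorded only as limits of the assay, not as numbers, and the step between them, hydroxy to methoxy, cannot be read. The compounds shown leave open whether any member of the series gives a numerical reading in this assay, and whether hydroxy to methoxy shifts that reading at all.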